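Compound 2 to compound 3: methylsulfanyl to methoxy

The source may hold more compounds than are shown below. What is called first, only, known or untested is meant among the compounds shown, and "the series" means these compounds.

Compound 1 `COc1cc(-c2ocnc2-c2cc(Br)c(OC)c(OC)c2)ccc1SC` gives 410 nM
Compound 2 `COc1ccc(-c2ocnc2-c2cc(Br)c(OC)c(OC)c2)cc1SC` gives 430 nM

In a functional assay on A-431 cells (Homo sapiens) for cytotoxicity, read by MTT assay, with a stated time of 48 h (on this read-out higher numbers stand for weaker inhibition and lower numbers for stronger inhibition), compound 2 gives 430 nM and stands within the scatter of compound 1 at 410 nM on the two numbers available. Compound 3 `COc1ccc(-c2ocnc2-c2cc(Br)c(OC)c(OC)c2)cc1OC` follows from compound 2 by one change methoxy in place of methylsulfanyl on an aromatic carbon with methoxy in place of methylsulfanyl on an aromatic carbon, ortho to a methoxy group. Among the measured compounds shown here, no measured pair shows this exchange, so only a modest move towards weaker inhibition in this assay is expected, an estimated 1.4-fold higher number from compound 2 to compound 3 (0.14 log units; within the scatter) overall. Compound 3 is estimated at 600 nM with an expected range of 150 nM to 2500 nM for the coming measurement.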

Compound 3, half-maximal inhibitory concentration: 12300 nM
Beside the measured number, compound 3's estimate is 21-fold (1.31 log units) below it; the measured number lies above the stated range.
By their numbers in this assay, from the lowest: compounds 1 and 2 (each within the scatter of the next); then compound 3.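

In this assay, methoxy in place of methylsulfanyl on an aromatic carbon, ortho to a methoxy group, gives a 29-fold higher number from compound 2 to compound 3 (1.46 log units; beyond the scatter) and so costs much activity at this position, although both groups have the same heavy-atom and hydrogen-bond acceptor counts. The same exchange gives a 30-fold higher number from compound 1 to compound 3 (1.48 log units; beyond the scatter) and thus a step of similar size, so the result does not depend on which of these two compounds is the reference. Nothing measured here accounts for the loss.

Still open, from the compounds shown here alone, is whether methylsulfanyl is specifically required at this position. A longer chain such as ethylsulfanyl, or an amine, could separate the contribution of the sulfur atom from that of the substituent's size.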